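The compounds below may be only part of what the source reports. "The series", "measured", "known", "first", "only" and "open" are said of these compounds alone.

Measured compounds in a functional assay on SGC-7901 cells (Homo sapiens) for antiproliferative activity, read by MTT assay, with a stated time of 48 h; on this read-out lower numbers stand for stronger inhibition and higher numbers for weaker inhibition:
- compound 1, `COc1cccc(C(=O)c2ccc(OC)c(OC(=O)CCC(=O)OC[C@@H]3C=C[C@H](n4cc(C)c(=O)[nH]c4=O)O3)c2)c1`: 770 nM
- compound 2, `COc1ccc(C(=O)c2cccc(Cl)c2)cc1OC(=O)CCC(=O)OC[C@@H]1C=C[C@H](n2cc(C)c(=O)[nH]c2=O)O1`: 4190 nM
- compound 3, `COc1ccc(C(=O)c2ccc([N+](=O)[O-])cc2)cc1OC(=O)CCC(=O)OC[C@@H]1C=C[C@H](n2cc(C)c(=O)[nH]c2=O)O1`: 10200 nM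

Compound 3 stands at the top of these three numbers, that is, it is the weakest of the set on this read-out. Its step from compound 1 is a 13-fold higher number from compound 1 to compound 3 (1.12 log units; beyond the scatter) and its step from compound 2 is a 2.4-fold higher number from compound 2 to compound 3 (0.39 log units; beyond the scatter), both beyond the scatter.

Compound 4, `COc1cc(OC)c(C(=O)c2ccc(OC)c(OC(=O)CCC(=O)OC[C@@H]3C=C[C@H](n4cc(C)c(=O)[nH]c4=O)O3)c2)cc1OC`, has not yet been measured. It differs from compound 3 in one place: 2,4,5-trimethoxyphenyl in place of 4-nitrophenyl on a carbonyl carbon.

Among the measured compounds shown here, two measured steps bear on this change, since both end at compound 3 and both exchange the aryl group on the same carbonyl carbon. The step of a 13-fold higher number from compound 1 to compound 3 (1.12 log units; beyond the scatter) shows that moving from a methoxy-bearing phenyl to the 4-nitrophenyl brought a large rise in the number, and the step of a 2.4-fold higher number from compound 2 to compound 3 (0.39 log units; beyond the scatter) shows a modest rise from the chloro-bearing phenyl. Compound 4 carries three methoxy groups on its phenyl, which points back toward the methoxy-bearing compound 1 rather than toward compound 3. The step of a 6.8-fold lower number from compound 3 to compound 4 (0.83 log units; beyond the scatter) is therefore expected to be a fall, probably large, though whether three methoxy groups behave like one is not known from these data. Compound 4 is estimated at 1500 nM, within a range of 400 nM to 6000 nM.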

Compound 4, half-maximal inhibitory concentration: 2270 nM
Estimate against measurement, compound 4: 1.5-fold (0.18 log units) below; the range from low to high includes it.
By their numbers in this assay, from the lowest: compound 1; then compounds 4 and 2 (each within the scatter of the next); then compound 3.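

In this assay the 2,4,5-trimethoxyphenyl group on the carbonyl carbon gives a clear gain over 4-nitrophenyl (a 4.5-fold lower number from compound 3 to compound 4 (0.65 log units; beyond the scatter)), which shows that this place accepts an aryl group carrying three methoxy groups without the loss seen with 4-nitrophenyl. It also shows that more methoxy groups do not bring a stronger result here: the 2,4,5-trimethoxyphenyl group falls short of 3-methoxyphenyl (a 2.9-fold higher number from compound 1 to compound 4 (0.47 log units; beyond the scatter)), and its exchange for 3-chlorophenyl (a 1.8-fold lower number from compound 2 to compound 4 (0.27 log units; within the scatter)) stays within the scatter, so these two groups cannot be put in order. Nothing available accounts for these differences.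

Since 3-methoxyphenyl and 2,4,5-trimethoxyphenyl differ both in the number of methoxy groups and in where they sit, the compounds shown do not tell which of the two matters. Going by these compounds, it also remains open how an amine or a carboxylic acid on this phenyl would behave, or how an ethoxy group would compare with methoxy.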